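The source may report more compounds than this note shows. Statements on the series, on what has been measured and on what is new or still open speak of the compounds shown alone.

Measured in an ADME assay (liver) for metabolic stability, with Liver microsome (Rattus norvegicus) as the target, using microsomes and NADPH, with a stated time of 30 min, at 37 degrees C, tested at 1 uM; on this read-out lower numbers stand for slow clearance and higher numbers for fast clearance:
Compound 1 `Nc1ccc(S(=O)(=O)c2ccc(-c3ccc(C(O)(C(F)(F)F)C(F)(F)F)cn3)cc2)cn1`: < 14 mL.min-1.g-1, a limit.
Compound 2 `CC(O)(c1ccc(-c2ccc(S(=O)(=O)c3ccc(N)nc3)cn2)nc1)C(F)(F)F`: < 14 mL.min-1.g-1, a limit.
Compound 3 `Nc1ccc(S(=O)(=O)c2ccc(-c3ncc(C(O)(C(F)(F)F)C(F)(F)F)cc3Cl)cc2)cn1`: 18 mL.min-1.g-1.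

Going by the values given here, compound 3 holds the only true number in this small set. Its two companions sit at the limit of < 14 mL.min-1.g-1 in this assay, at which 2 of the 3 values shown sit. Compound 4 `COc1cc(C(O)(C(F)(F)F)C(F)(F)F)cnc1-c1ccc(S(=O)(=O)c2ccc(N)nc2)cc1` has methoxy in place of chloro on an aromatic carbon, ortho to a large group: methoxy in place of chloro on an aromatic carbon. Among the compounds with values here, one measured step touches this place, an at least 1.2-fold higher number from compound 1 to compound 3 (0.10 log units; that floor lies within the scatter). That step brought in chloro for hydrogen, so it says nothing directly about methoxy, and it gives no direction for the new change. The expected change is therefore no more than the scatter, an estimated 1.1-fold higher number from compound 3 to compound 4 (0.05 log units; within the scatter). For compound 4 the estimate in this assay is 20 mL.min-1.g-1, with an expected range of 10 mL.min-1.g-1 to 40 mL.min-1.g-1.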

Compound 4, intrinsic clearance in microsomes: < 14 mL.min-1.g-1
Compound 4: no number, only a limit; the forecaster's own chance of this, stated with the estimate: 30%; middle value at least 1.4-fold (0.15 log units) away from the limit.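

In this assay, the place ortho to a large group now carries a second group, methoxy, and the change from chloro reads as an at least 1.2-fold lower number from compound 3 to compound 4 (0.10 log units; that floor lies within the scatter). Compound 4 gives only a limit, so methoxy leaves no true number at this place, where chloro gave one. Most of the set now sits at one floor: the limit of < 14 mL.min-1.g-1 in this assay, at which 3 of the 4 values shown sit.

The step from compound 1 to compound 4 cannot be read, since both values are limits. On these data alone, how fluoro, an amine or a longer chain such as ethoxy would read at this place stays open.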